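The source may hold more compounds than are shown below. What is called first, only, known or untested is meant among the compounds shown, and "the series" means these compounds.

Compound 1 `CCC(C)/N=C(\C)c1c(O)c2ccccc2oc1=O`: >= 100000 nM
Compound 2 `CCC/C(=N\Cc1ccccc1)c1c(O)c2ccccc2oc1=O`: >= 100000 nM

The read-out throughout is an assay on isolated protein for inhibition of myosin-2 (Bos taurus), read by spectrophotometry, with a stated time of 24 min; on this read-out higher numbers stand for weaker inhibition and lower numbers for stronger inhibition. Compound 1 shows only a limit of the assay, >= 100000 nM. Compound 2 likewise shows only a limit of the assay, >= 100000 nM. Within the data shown here, no step between the two measured compounds is computed, as they differ in more than one place; both values sit at the limit of >= 100000 nM in this assay, at which 2 of the 2 values shown sit, so there is no number against which compound 1 can be ranked. Compound 1 thus stands at the limit, indistinguishable from the other measured entry.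

Compound 3 `C/C(=N\CCO)c1c(O)c2ccccc2oc1=O` differs from compound 1 by 2-hydroxyethyl in place of sec-butyl on a double-bonded nitrogen. Among the measured compounds shown here, with no measured step and only limits on hand, no direction or size of change beyond the scatter can be expected from this replacement; the expected step is a number no higher from compound 1 to compound 3 (the limit leaves the size open), that is, none beyond the scatter. Compound 3 is expected to give 100000 nM in this assay, within a range from 30000 nM to 300000 nM, and most likely again reported only as a limit rather than a number.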

Compound 3, half-maximal inhibitory concentration: 92000 nM
Compound 3: middle estimate off by 1.1-fold (0.04 log units), on the high side; the range from low to high includes it.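

In this assay, compound 3 gives 92000 nM, the only number in the series shown rather than a limit, so a value can now be read with the oxygen-bearing 2-hydroxyethyl on the double-bonded nitrogen. From the compounds shown here alone, the change from sec-butyl reads as an at least 1.0-fold lower number from compound 1 to compound 3 (0.03 log units; that floor lies within the scatter), which shows no gain beyond the scatter, though the true size of the step remains open. The remaining entries still provide no number for comparison, only a limit: the limit of >= 100000 nM in this assay, at which 2 of the 3 values shown sit.

Going by these compounds, whether the number for compound 3 goes with the hydroxyl of 2-hydroxyethyl or with the chain itself remains open, and a plain ethyl or a 2-aminoethyl group on the same nitrogen would separate the two readings. On these data alone, it is also open whether any replacement at this position can move the value clearly beyond the scatter, for example a carboxylic acid at the end of the chain or a longer chain ending in hydroxyl.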